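The source may report more compounds than this note shows. Statements on the series, on what has been measured and on what is new or still open speak of the compounds shown alone.

Compound 1, whose structure is `COc1ccccc1Nc1nc(-c2cccc(F)c2)nc2ccc(F)cc12`, is one of three close relatives that share a core and differ only in the ring attached to a nitrogen on that core. In a functional assay on HL-60 cells (Homo sapiens) for cytotoxicity, read by MTT assay, with a stated time of 48 h (on this read-out higher numbers stand for weaker inhibition and lower numbers for stronger inhibition), compound 1 gives > 50000 nM, which is a limit of the assay rather than a number. Compound 2 `Fc1cccc(-c2nc(Nc3ccc(Cl)cc3)c3cc(F)ccc3n2)c1` carries a 4-chlorophenyl on that nitrogen, and in this assay compound 2 gives 45700 nM. Compound 3 `Fc1cccc(-c2nc(Nc3cccc(Cl)c3)c3cc(F)ccc3n2)c1` carries a 3-chlorophenyl on the same nitrogen, and in this assay compound 3 gives > 50000 nM, again a limit of the assay. The step of an at least 1.0-fold lower number from compound 1 to compound 2 (0.03 log units; that floor lies within the scatter) shows how little the 4-chlorophenyl changes here, the step of an at least 1.0-fold higher number from compound 2 to compound 3 (0.03 log units; that floor lies within the scatter) the same for the move to 3-chlorophenyl, and the step that the two limits leave unreadable from compound 1 to compound 3 cannot be sized because of the limit of > 50000 nM in this assay, at which 2 of the 3 values shown sit.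

Compound 4 `Fc1cccc(-c2nc(Nc3cccc(Br)c3)c3cc(F)ccc3n2)c1` has not been measured. Its difference from compound 1 is 3-bromophenyl in place of 2-methoxyphenyl on a nitrogen on an aromatic ring. The nearest measured guide is compound 3 with a 3-chlorophenyl in the same place, and it sat at the limit. In this assay compound 4 is therefore expected to give about 60000 nM, most likely again as a limit, within 30000 nM to 200000 nM. The step that the limit leaves unreadable from compound 1 to compound 4 is expected to be none beyond the scatter.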

Compound 4, half-maximal inhibitory concentration: > 50000 nM
Compound 4 gave a limit, no number (the forecaster's own chance of this, stated with the estimate: 75%); the middle value lies beyond the limit too.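

The new change is bromo in place of chloro on an aromatic carbon, and in this assay compound 4 still gives only a limit of the assay, so the heavier halogen on this ring brings no readable number. Compound 2 remains the only one of the four with an actual value, and the comparison with it gives an at least 1.0-fold higher number from compound 2 to compound 4 (0.03 log units; that floor lies within the scatter), so the 3-bromophenyl and the 4-chlorophenyl on this nitrogen cannot be told apart. The steps from compound 1 and from compound 3 to compound 4 cannot be read because both ends of each are limits: the limit of > 50000 nM in this assay, at which 3 of the 4 values shown sit.

Open, going by these compounds, is whether a ring on this nitrogen carrying an amine or a carboxylic acid instead of a halogen or methoxy would give a value clearly under that limit in this assay. Also open, on these data alone, is how far bromo and chloro really differ at this place, which only values under the limit could show.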